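Chloro removal on the aryl piperazine of compound 3

This account rests on a few compounds, and the source may have more. Where it says the series, first, only, none or still open, it means among the compounds named here.

Working notes on the aryl piperazine sulfonamides read in an assay on CHO cells for displacement of a labelled ligand from adenosine receptor A1 (Homo sapiens), read by scintillation counting, with a stated time of 90 min, in the presence of a further agent that is not named here; a higher number here means a weaker inhibitor, a lower number a stronger inhibitor.

Compound 1 `CCCn1c(=O)c2[nH]c(-c3ccc(S(=O)(=O)N4CCN(c5ccc(Cl)cc5)CC4)cc3)nc2n(C)c1=O` is one of three measured members of the set. Compound 2 `CCCn1c(=O)[nH]c2nc(-c3ccc(S(=O)(=O)N4CCN(c5ccccc5)C(C)C4)cc3)[nH]c2c1=O` and compound 3 `CCCn1c(=O)[nH]c2nc(-c3ccc(S(=O)(=O)N4CCN(c5ccc(Cl)cc5F)CC4)cc3)[nH]c2c1=O` share the same core with compound 1 and differ from it in the aryl group on the piperazine. In this assay compound 1 reports only a limit, > 1000 nM. Compound 2 likewise reports only a limit, > 1000 nM. Compound 3 also stops at a limit, > 1000 nM. Among the compounds with values here, none of the three resolves to a number, so compound 3 stands at the limit together with the other two, and no step between measured compounds can be drawn (the limit of > 1000 nM in this assay, at which 3 of the 3 values shown sit).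

Compound 4 `CCCn1c(=O)[nH]c2nc(-c3ccc(S(=O)(=O)N4CCN(c5ccccc5F)CC4)cc3)[nH]c2c1=O` carries hydrogen in place of chloro on an aromatic carbon. Within the data shown here, with every measured value at the limit, no step points in either direction; the expected step is a step that the limit leaves unreadable from compound 3 to compound 4, small or none beyond the scatter. Compound 4 is therefore expected to remain weak, estimated at 3000 nM with a range of 800 nM to 20000 nM in this assay, most likely reported again as a limit.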

Compound 4, inhibition constant: > 1000 nM
Compound 4 gave a limit, no number; the forecaster's own chance of this, stated with the estimate: 80%; the middle value lies beyond the limit too.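

In this assay compound 4 gives > 1000 nM, a limit and not a number. Compound 3 also stands at a limit, so no step between compound 3 and compound 4 can be read: the limit of > 1000 nM in this assay, at which 4 of the 4 values shown sit.

The compounds shown leave open whether the chloro on the aryl piperazine affects inhibition in this assay at all.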